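Carbamate variation on a shared quinazoline-free core: stability notes

The source may hold more compounds than are shown below. What is called first, only, known or untested is meant among the compounds shown, and "the series" means these compounds.

Measured compounds:
- compound 1 `C[C@@H]1CN(C(=O)c2nc(Nc3cc(C4CC4)[nH]n3)c3cc(Cl)ccc3n2)CCN1C(=O)OC(C)(C)C`: 71.3%
- compound 2 `CC(OC(=O)N1CCN(C(=O)c2nc(Nc3cc(C4CC4)[nH]n3)c3cc(Cl)ccc3n2)C[C@H]1C)OC(=O)C(C)(C)C`: 66.3%
- compound 3 `C[C@@H]1CN(C(=O)c2nc(Nc3cc(C4CC4)[nH]n3)c3cc(Cl)ccc3n2)CCN1C(=O)OCc1ccccc1`: 45.6%

In an ADME assay on S9 fraction from liver (Rattus norvegicus), read by LC-MS, with a stated time of 60 min, at 37 degrees C (on this read-out lower numbers stand for a less stable compound and higher numbers for a more stable compound), compound 1 gives the highest of the three numbers; compound 2 sits within the scatter of it, and compound 3 lies beyond the scatter below it. Compound 4 `C[C@@H]1CN(C(=O)c2nc(Nc3cc(C4CC4)[nH]n3)c3cc(Cl)ccc3n2)CCN1C(=O)OCOC(=O)C(C)(C)C` carries the change ((((tert-butyl)carbonyl)oxy)methyl in place of tert-butyl on an oxygen next to a carbonyl group). Within the data shown here, two steps bear on it. The step of a number 5 percentage points lower from compound 1 to compound 2 (within the scatter) introduces a related carbonyloxyalkyl group on the same oxygen and stays within the scatter. The step of a number 25.7 percentage points lower from compound 1 to compound 3 (beyond the scatter) is modest and downward. The change to compound 4 resembles the former more than the latter, so a step of at most modest size downward, possibly none beyond the scatter, is expected in this assay. The expected step is a number 8.3 percentage points lower from compound 1 to compound 4 (within the scatter). Compound 4 is estimated at 63%, with a range of 45% to 78%.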

Compound 4, percent of the compound remaining: 47%
Estimate against measurement, compound 4: 16 percentage points above; the measured number falls inside the stated range.
By their numbers in this assay, from the lowest: compounds 3 and 4 (each within the scatter of the next); then compounds 2 and 1 (each within the scatter of the next).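

In this assay the (((tert-butyl)carbonyl)oxy)methyl group on this oxygen gives a number 24.3 percentage points lower from compound 1 to compound 4 (beyond the scatter), so a carbonyloxyalkyl group here does not always stay within the scatter of tert-butyl. The methyl on the saturated chain carbon bound to two oxygens makes the difference between the two such groups, with a number 19.3 percentage points lower from compound 2 to compound 4 (beyond the scatter), while ((tert-butyl)carbonyl)oxy in place of phenyl gives a number 1.4 percentage points higher from compound 3 to compound 4 (within the scatter). No evidence on the cause of these steps is available. Still open, as far as these compounds go, is how an ethyl group on that chain carbon, or an amine in the ester part, would read.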